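Isopropyl in place of oxan-4-yl on compound 3

The compounds below may be only part of what the source reports. "The series", "measured", "known", "first", "only" and "open" are said of these compounds alone.

Measured so far in a functional assay on BT-474 cells (Homo sapiens) for inhibition, read by MTT assay, with a stated time of 5 days (on this read-out higher numbers stand for weaker inhibition and lower numbers for stronger inhibition), as follows

compound 1 `Cc1cc(Nc2nc(NCc3ccc(F)cc3)nc3[nH]ncc23)n[nH]1` gives 8750 nM
compound 2 `COc1ccc(CNc2nc(Nc3cc(C)[nH]n3)c3cn[nH]c3n2)cc1` gives 8230 nM
compound 3 `Cc1cc(Nc2nc(NCc3ccc(Cl)cc3)nc3c2cnn3C2CCOCC2)n[nH]1` gives 18300 nM

Compound 3 has the highest of the three numbers, beyond the scatter from both compound 1 and compound 2. The next structure, compound 4 `Cc1cc(Nc2nc(NCc3ccc(Cl)cc3)nc3c2cnn3C(C)C)n[nH]1`, carries isopropyl in place of oxan-4-yl on an aromatic nitrogen of the shared core.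

Going by the values given here, the only measured step, a 1.1-fold lower number from compound 1 to compound 2 (0.03 log units; within the scatter), lies within the scatter and sits at another place, so it bears on this change only weakly. Among the compounds with values here, no measured pair isolates the group on this nitrogen. Compound 3 differs from compound 1 and compound 2 in more than one place, so its gap to them cannot be assigned to that group alone.

No step beyond the scatter is therefore expected in this assay, and neither direction is favoured. The expected step is a 1.2-fold lower number from compound 3 to compound 4 (0.09 log units; within the scatter) on this reading. Compound 4 is estimated at 15000 nM, with an expected range of 6000 nM to 35000 nM for now.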

Compound 4, half-maximal inhibitory concentration: 13000 nM
For compound 4 the middle estimate is 1.2-fold (0.06 log units) above the measured one; measured number inside the range.
By their numbers in this assay, from the lowest: compounds 2, 1, 4 and 3 (each within the scatter of the next, the first and the last beyond it).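

In this assay the exchange on the aromatic nitrogen gives a 1.4-fold lower number from compound 3 to compound 4 (0.15 log units; within the scatter) and so stays within the scatter. Going by these compounds alone, this is the first pair to isolate the group at this place: with the chloro-bearing side of the molecule held constant, oxan-4-yl with its ring and hydrogen-bond acceptor and the smaller, ring-free isopropyl cannot be told apart on this read-out. No measurement shown offers an explanation for this result.

From the compounds shown here alone, whether an amine, a carboxylic acid or a longer chain on this nitrogen would move the number beyond the scatter stays open. Also open, going by these compounds, is what any group here contributes relative to the free ring nitrogen, as compound 1 and compound 2 differ from compound 3 and compound 4 in more than one place.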